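A few compounds are considered here, and "the series" means these few. Any claim that something is new, unique, unknown or untested is made for them only; others in the source may bear on it.

Measured so far:
Compound 1, `[O-][S+](CCCCN=C=S)Cc1ccccc1`: in a functional assay on SH-SY5Y cells (Homo sapiens) for cytotoxicity, read by MTT assay, with a stated time of 72 h (a lower number here means a stronger inhibitor, a higher number a weaker inhibitor), compound 1 gives 5210 nM.
Compound 2, `[O-][S+](CCCN=C=S)Cc1ccccc1`: in this assay compound 2 gives 8890 nM.
Compound 3, `CC(C)[S+]([O-])CCCCCN=C=S`: in this assay compound 3 gives 8620 nM.

Compound 1 and compound 2 share a core and differ in one place: a group of 4 heavy atoms (2 carbon, 1 nitrogen, 1 sulfur; no ring) in place of a group of 3 heavy atoms (1 carbon, 1 nitrogen, 1 sulfur; no ring), on a saturated chain carbon, three bonds along the chain from a sulfur. That change produced a 1.7-fold lower number from compound 2 to compound 1 (0.23 log units; within the scatter), a step that stays within the usual scatter of repeated measurements. Compound 3 has a different core from compound 2, and the difference between the two cores is not broken down here; the value of compound 3 and the value of compound 2 lie within the scatter of one another, so nothing can be said about an order between them.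

Compound 4, `CC(C)[S+]([O-])CCCCCCN=C=S`, has not yet been measured. It differs from compound 3 by a group of 4 heavy atoms (2 carbon, 1 nitrogen, 1 sulfur; no ring) in place of a group of 3 heavy atoms (1 carbon, 1 nitrogen, 1 sulfur; no ring), on a saturated chain carbon, five bonds along the chain from a sulfur. For the measured compounds named here, this is the same kind of change as the one from compound 2 to compound 1, but not the same: there the change sits three bonds along the chain from a sulfur, here it sits five bonds along the chain from a sulfur. Going by the values given here, with only the single earlier example to rest on, the step expected from compound 3 to compound 4 is of the same size as the earlier one, that is a 1.4-fold lower number from compound 3 to compound 4 (0.16 log units; within the scatter), because a 1.7-fold lower number from compound 2 to compound 1 (0.23 log units; within the scatter) was itself within the scatter. On that basis compound 4 is estimated to give 6000 nM in this assay, with a likely range from 2500 nM to 14000 nM.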

Compound 4, half-maximal inhibitory concentration: 7820 nM
Compound 4: middle estimate off by 1.3-fold (0.12 log units), on the low side; the range from low to high includes it.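

In this assay, the new step is a 1.1-fold lower number from compound 3 to compound 4 (0.04 log units; within the scatter), made by putting a group of 4 heavy atoms (2 carbon, 1 nitrogen, 1 sulfur; no ring) in place of a group of 3 heavy atoms (1 carbon, 1 nitrogen, 1 sulfur; no ring), on a saturated chain carbon, five bonds along the chain from a sulfur. Set beside the earlier step, which sits three bonds along the chain from a sulfur, this step gives no sign that the change acts differently on the two cores: the same change on two cores in this assay, a 1.7-fold lower number (0.23 log units; within the scatter) from compound 2 to compound 1 and a 1.1-fold lower number (0.04 log units; within the scatter) from compound 3 to compound 4, 1.5-fold (0.19 log units) apart, within the scatter of two such steps It does not show that the change carries over as a real effect, as each step on its own stays within the scatter, and two cores are a narrow basis for any wider statement about the series.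

The compounds shown leave open whether a longer chain on either core would give a step that rises clear of the scatter. They also leave open what an amine or a carboxylic acid would give in place of the group that changes here.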